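Cytotoxicity notes: from compound 2 to compound 3

The compounds below may be only part of what the source reports. "The series", "measured", "known", "first", "only" and "open" are said of these compounds alone.

Compound 2 `COc1ccc(F)cc1CNCCCNc1ccnc2cc(Cc3ccc(F)cc3Cl)ccc12` gives 2460 nM in an ADME assay on HepG2 cells (Homo sapiens) for cytotoxicity, read by luminescence, CellTiter-Glo and ATP content, with a stated time of 72 h; on this read-out lower numbers stand for an effect already at smaller amounts and higher numbers for an effect only at larger amounts of compound. Compound 1 `COc1ccc(F)cc1CNCCCNc1ccnc2cc(CCc3ccccc3)ccc12` gives 4240 nM in this assay, and the step of a 1.7-fold lower number from compound 1 to compound 2 (0.24 log units; within the scatter) leaves the two indistinguishable. Compound 3 `COc1ccc(F)cc1CNCCCNc1ccnc2cc(-c3ccc(F)cc3)ccc12` differs from compound 2 by 4-fluorophenyl in place of 2-chloro-4-fluorobenzyl on an aromatic carbon. For the measured compounds named here, no measured step touches this part of the core in this way, and the only step recorded, a 1.7-fold lower number from compound 1 to compound 2 (0.24 log units; within the scatter), stayed within the scatter. No movement beyond the scatter is therefore expected, and the step from compound 2 to compound 3 is estimated as a 1.2-fold higher number from compound 2 to compound 3 (0.09 log units; within the scatter). Compound 3 is expected at 3000 nM, with a range from 1000 nM to 9000 nM.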

Compound 3, half-maximal effective concentration: 770 nM
Compound 3: the middle estimate sits 3.9-fold (0.59 log units) above what was measured; the measured number lies below the stated range.
By their numbers in this assay, from the lowest: compound 3; then compounds 2 and 1 (each within the scatter of the next).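

In this assay this position now shows a change beyond the scatter: a 3.2-fold lower number from compound 2 to compound 3 (0.50 log units; beyond the scatter) and a 5.5-fold lower number from compound 1 to compound 3 (0.74 log units; beyond the scatter) both come with 4-fluorophenyl on the aromatic carbon. The replaced groups, 2-chloro-4-fluorobenzyl and phenethyl, stay within the scatter of each other, so among these three compounds only 4-fluorophenyl stands apart. Nothing at hand accounts for the shift.

Going by these compounds, the step to compound 3 removes the chlorine and the saturated carbon together, so their separate shares remain unknown. On these data alone, how an amine or a carboxylic acid on this aromatic carbon would read also stays open.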